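From 3-nitrophenyl to thiophen-3-yl on the shared core

This account rests on a few compounds, and the source may have more. Where it says the series, first, only, none or still open, it means among the compounds named here.

Measured in a functional assay on FM3A cells (Mus musculus) for antiproliferative activity; a higher number here means a weaker inhibitor, a lower number a stronger inhibitor:
Compound 1 `COc1ccc(-c2cc(N)c(C(=O)c3cc(OC)c(OC)c(OC)c3)s2)cc1OC`: 72 nM
Compound 2 `COc1cc(C(=O)c2sc(-c3ccc(I)cc3)cc2N)cc(OC)c1OC`: 420 nM
Compound 3 `COc1cc(C(=O)c2sc(-c3cccc([N+](=O)[O-])c3)cc2N)cc(OC)c1OC`: 17 nM

Among these three, compound 3 has the lowest number, and its steps to both others lie beyond the scatter. The next compound, compound 4 `COc1cc(C(=O)c2sc(-c3ccsc3)cc2N)cc(OC)c1OC`, keeps the shared core and carries thiophen-3-yl in place of 3-nitrophenyl on an aromatic carbon, next to the ring sulfur (thiophen-3-yl in place of 3-nitrophenyl on an aromatic carbon).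

All three measured steps concern this same place. The first runs a 4.2-fold lower number from compound 1 to compound 3 (0.63 log units; beyond the scatter) and the second 25-fold lower number from compound 2 to compound 3 (1.39 log units; beyond the scatter), while the third runs a 5.8-fold higher number from compound 1 to compound 2 (0.77 log units; beyond the scatter). The group on this carbon therefore moves this assay by modest to large amounts. Within the data shown here, no measured compound carries a thiophen-3-yl group, so none of these steps predicts the new change directly. Both other groups give higher numbers than the 3-nitrophenyl group, with compound 1 at 72 nM and compound 2 at 420 nM in the same read-out. A modest step to a higher number is therefore expected, though the range stays wide. The expected change is a 4.1-fold higher number from compound 3 to compound 4 (0.61 log units; beyond the scatter) on this estimate. For compound 4 the estimated value is 70 nM, with an expected range from 15 nM to 300 nM.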

Compound 4, half-maximal inhibitory concentration: 3.7 nM
Beside the measured number, compound 4's estimate is 19-fold (1.28 log units) above it, outside the stated range (below it).
By their numbers in this assay, from the lowest: compound 4; then compound 3; then compound 1; then compound 2.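

In this assay, compound 4 is the strongest inhibitor of the four, with a 4.6-fold lower number from compound 3 to compound 4 (0.66 log units; beyond the scatter), and the gaps from the two weaker compounds are wider still, with a 19-fold lower number from compound 1 to compound 4 (1.29 log units; beyond the scatter) and a 110-fold lower number from compound 2 to compound 4 (2.06 log units; beyond the scatter). Among these compounds, the earlier compounds all carried a six-membered aromatic ring of carbon only on this carbon, so they showed only that the groups on that ring move the number; compound 4 shows that such a ring is not needed here, since a five-membered aromatic ring with one sulfur gives the lowest number of the set. Nothing shown gives a measured reason for this drop.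

The change from compound 3 to compound 4 alters the ring and removes the nitro group in a single step, so the compounds shown cannot separate what each contributes, and unsubstituted phenyl would be the group that speaks to this. They also leave open whether the attachment point or the ring sulfur matters, which thiophen-2-yl and furan-3-yl on the shared core would address.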